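A Hydroxyl Moved Around the Ring: Compound 3 to Compound 4

The source may report more compounds than this note shows. Statements on the series, on what has been measured and on what is new or still open speak of the compounds shown alone.

Of the compounds shown here, three sharing one core have been tested in an ADME assay on HEK293 cells (Homo sapiens) for cytotoxicity, read by CCK-8 assay and cell counting, with a stated time of 2 days; a higher number here means a weaker inhibitor, a lower number a stronger inhibitor. Compound 1 `Oc1ccc(-c2cc(-c3ccc(Cl)cc3)nc(-c3cccnc3)c2)cc1` gives 27500 nM, compound 2 `Oc1ccc(-c2cc(-c3cccs3)nc(-c3ccccc3Cl)c2)cc1` gives 5220 nM, and compound 3 `Oc1cccc(-c2cc(-c3ccc(Cl)cc3)nc(-c3cccs3)c2)c1` gives 11800 nM. Compound 3 stands second highest of the three: its number is higher than that of compound 2 and lower than that of compound 1, and both gaps lie beyond the usual scatter.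

Compound 4 `Oc1ccc(-c2cc(-c3ccc(Cl)cc3)nc(-c3cccs3)c2)cc1` differs from compound 3 in one place: 4-hydroxyphenyl in place of 3-hydroxyphenyl on an aromatic carbon. The two compounds contain the same atoms, joined differently, so the change is only where the hydroxyl sits on that ring. Within the data shown here, no pair of measured compounds differs by this change alone, so its effect cannot be read directly from the data. Compounds 1 and 2, which both carry the 4-hydroxyphenyl group, sit on either side of compound 3 in this assay, which points to a small step. The expected step from compound 3 to compound 4 is a 1.2-fold higher number from compound 3 to compound 4 (0.07 log units; within the scatter), within the scatter. Compound 4 is estimated at 14000 nM, with a range from 6000 nM to 35000 nM.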

Compound 4, half-maximal inhibitory concentration: 4520 nM
Beside the measured number, compound 4's estimate is 3.1-fold (0.49 log units) above it; the whole stated range lies above it.
By their numbers in this assay, from the lowest: compounds 4 and 2 (each within the scatter of the next); then compound 3; then compound 1.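

In this assay the hydroxyl's place on this ring proves to matter: with the same atoms, 4-hydroxyphenyl in place of 3-hydroxyphenyl gives a 2.6-fold lower number from compound 3 to compound 4 (0.42 log units; beyond the scatter) and so a step beyond the scatter. With 4-hydroxyphenyl held fixed, the other two changes differ in size: 4-chlorophenyl in place of 2-chlorophenyl gives only a 1.2-fold lower number from compound 2 to compound 4 (0.06 log units; within the scatter) and stays within the scatter. By contrast, thiophen-2-yl in place of pyridin-3-yl gives a 6.1-fold lower number from compound 1 to compound 4 (0.78 log units; beyond the scatter) and so reaches beyond it.

No measurement here gives a reason for these differences. It also stays open whether the number at this position depends on the hydroxyl itself, as the compounds shown include no amine or carboxylic acid on this ring to compare with it.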